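Methyl to hydrogen on the aryl ether of compound 2

This account rests on a few compounds, and the source may have more. Where it says the series, first, only, none or still open, it means among the compounds named here.

For the measured compounds named here, in a functional assay on HepG2 cells (Homo sapiens) for cytotoxicity, read by MTT assay, with a stated time of 48 h (a higher number here means a weaker inhibitor, a lower number a stronger inhibitor), compound 2 `COc1cc2c(cc1OC)CN(S(=O)(=O)c1ccc(-n3cc(COc4ccc(C)cc4)nn3)cc1)CC2` gives 560 nM, the lowest of the three numbers measured so far. Going by the values given here, compound 1 `COc1cc2c(cc1OC)CN(S(=O)(=O)c1ccc(-n3cc(COc4ccc5ccccc5c4)nn3)cc1)CC2` gives 1260 nM in this assay, and compound 3 `O=S(=O)(c1ccc(-n2cc(COc3ccc4ccccc4c3)nn2)cc1)N1CCc2ccccc2C1` gives 60500 nM; compounds 1 and 3 differ in the saturated ring portion rather than at the aryl ether, and no counted step joins them, so their two values are only noted as they stand. Among the compounds with values here, the one measured step that touches the aryl ether is a 2.3-fold lower number from compound 1 to compound 2 (0.35 log units; beyond the scatter), beyond the scatter but modest.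

Compound 4 `COc1cc2c(cc1OC)CN(S(=O)(=O)c1ccc(-n3cc(COc4ccccc4)nn3)cc1)CC2` differs from compound 2 by hydrogen in place of methyl on an aromatic carbon. Within the data shown here, no measured step removes a methyl from this ring; the nearest comparison, the move from naphthalen-2-yl to 4-methylphenyl between compound 1 and compound 2, was modest, and the present change of a single carbon is smaller still. A step near or within the scatter is therefore expected, with no firm direction. For compound 4 the estimate in this assay is 700 nM, with a range from 300 nM to 1800 nM, corresponding to an expected step of a 1.3-fold higher number from compound 2 to compound 4 (0.10 log units; within the scatter).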

Compound 4, half-maximal inhibitory concentration: 2570 nM
Estimate against measurement, compound 4: 3.7-fold (0.56 log units) below; measured number above the stated range.
By their numbers in this assay, from the lowest: compound 2; then compound 1; then compound 4; then compound 3.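

In this assay, the methyl para to a large group is not a silent substituent: replacing it with hydrogen gives a 4.6-fold higher number from compound 2 to compound 4 (0.66 log units; beyond the scatter), so one carbon at this position moves the number beyond the scatter. Phenyl also compares unfavourably with naphthalen-2-yl, with a 2.0-fold higher number from compound 1 to compound 4 (0.31 log units; beyond the scatter), so both substituted aryl ethers on this core give lower numbers than the plain phenoxymethyl ether. No evidence here accounts for the effect of the methyl.

As far as these compounds go, it remains open whether a methoxy, a chlorine, an amine or a carboxylic acid at the same position would keep the lower number or whether a longer chain such as ethyl would lower it further. From the compounds shown here alone, it is also open whether the methyl step carries over to the core of compound 3.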